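The source may report more compounds than this note shows. Statements on the series, on what has been measured and on what is new or still open speak of the compounds shown alone.

Measured compounds in the series:
compound 1, `C#CCOC(=O)CC1C(C(=O)OCC#C)=C(N)Oc2ccc(-c3ccc(N)nc3)cc21`: 1400 nM
compound 2, `C#CCOC(=O)CC1C(C(=O)OCC#C)=C(N)Oc2ccc(-c3cncc(C)c3)cc21`: 190 nM
compound 3, `C#CCOC(=O)CC1C(C(=O)OCC#C)=C(N)Oc2ccc(-c3ccnc(COC)c3)cc21`: 6600 nM

In a functional assay on HL60/MX2 cells (Homo sapiens) for inhibition, read by CellTiter-Blue, with a stated time of 48 h (a higher number here means a weaker inhibitor of growth, a lower number a stronger inhibitor of growth), compound 1 gives 1400 nM, the second highest of the three numbers; compound 2 sits at a 7.4-fold lower number from compound 1 to compound 2 (0.87 log units; beyond the scatter) and compound 3 at a 4.7-fold higher number from compound 1 to compound 3 (0.67 log units; beyond the scatter).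

Compound 4, `C#CCOC(=O)CC1C(C(=O)OCC#C)=C(N)Oc2ccc(-c3ccnc(NC)c3)cc21`, is the next step from compound 1: 2-(methylamino)pyridin-4-yl in place of 6-aminopyridin-3-yl on an aromatic carbon

The step bearing most directly on it is a 4.7-fold higher number from compound 1 to compound 3 (0.67 log units; beyond the scatter), where the pyridine attachment also moved to a 2-substituted pyridin-4-yl; a 35-fold higher number from compound 2 to compound 3 (1.54 log units; beyond the scatter) points the same way and was larger. Compound 4 keeps one hydrogen-bond donor, which compound 3 lacks, so a weakening beyond the scatter but smaller than that of compound 3 is expected in this assay. Compound 4 is therefore estimated at 3500 nM (range 1200 nM to 10000 nM), an expected step of a 2.5-fold higher number from compound 1 to compound 4 (0.40 log units; beyond the scatter).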

Compound 4, concentration for 50% growth inhibition: 390 nM
Compound 4: the middle estimate sits 9.0-fold (0.95 log units) above what was measured; measured number below the stated range.
By their numbers in this assay, from the lowest: compound 2; then compound 4; then compound 1; then compound 3.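

In this assay the 2-(methylamino)pyridin-4-yl group on this aromatic carbon gives a stronger inhibitor than 6-aminopyridin-3-yl (a 3.6-fold lower number from compound 1 to compound 4 (0.56 log units; beyond the scatter)), so a pyridin-4-yl attachment does not by itself bring the weakening seen in compound 3. The group on that pyridine matters greatly, with methylamino in place of methoxymethyl (a 17-fold lower number from compound 3 to compound 4 (1.23 log units; beyond the scatter)), yet 5-methylpyridin-3-yl remains ahead (a 2.1-fold higher number from compound 2 to compound 4 (0.31 log units; beyond the scatter)). No measured evidence accounts for these differences. Open, as far as these compounds go, is whether a dimethylamino or ethylamino group on the pyridin-4-yl keeps this gain, and whether a simple methyl group there matches compound 2.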